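Replacing Cyano with Acetamido: An Expected Value

The source may hold more compounds than are shown below. What is called first, only, known or untested is meant among the compounds shown, and "the series" means these compounds.

Measured so far:
compound 1, `Cc1nc(-c2ccc(F)cc2)c(C(=O)N2CCN(c3cccc(Cl)c3)CC2)o1`: 40.1 nM
compound 2, `Cc1nc(-c2ccccc2)c(C(=O)N2CCN(c3cccc(C#N)c3)CC2)o1`: 39.6 nM

In a functional assay on HL-60 cells (Homo sapiens) for inhibition, read by MTT assay, with a stated time of 72 h (on this read-out lower numbers stand for stronger inhibition and higher numbers for weaker inhibition), compound 2 gives a number that sits together with that of compound 1, the two lying within the usual scatter, so neither can be called the stronger. Compound 3, `CC(=O)Nc1cccc(N2CCN(C(=O)c3oc(C)nc3-c3ccccc3)CC2)c1`, carries a single change from compound 2: acetamido in place of cyano on an aromatic carbon. Going by the values given here, no pair of measured compounds shows this change, so its effect is unknown here. The group entering brings a hydrogen-bond donor and more heavy atoms than the cyano it replaces. The step of a 1.8-fold higher number from compound 2 to compound 3 (0.25 log units; within the scatter) is expected to be small, toward weaker inhibition or none beyond the scatter. Compound 3 is therefore estimated at 70 nM, with a range from 25 nM to 250 nM.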

Compound 3, half-maximal inhibitory concentration: 329 nM
The estimate for compound 3 lay 4.7-fold (0.67 log units) below the measured number, outside the stated range (above it).
By their numbers in this assay, from the lowest: compounds 2 and 1 (each within the scatter of the next); then compound 3.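

In this assay, the aromatic carbon bearing the cyano group proved sensitive to what sits on it: going from 3-cyanophenyl to 3-acetamidophenyl gives an 8.3-fold higher number from compound 2 to compound 3 (0.92 log units; beyond the scatter), toward weaker inhibition. This single exchange, which adds a hydrogen-bond donor and more heavy atoms, is enough to move the number beyond the scatter. Nothing available here explains the loss. The compounds shown leave open whether the change follows the amide hydrogen, the added atoms or both. An amine or a methoxy group on the same carbon would help separate these possibilities.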